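Hydroxyphenyl pyridine series: cytotoxicity notes toward compound 4

The source may hold more compounds than are shown below. What is called first, only, known or untested is meant among the compounds shown, and "the series" means these compounds.

Measured compounds:
compound 1 `Oc1cccc(-c2cc(-c3cccnc3)nc(-c3cccc(Cl)c3)c2)c1` — "not determined" (no result reported)
compound 2 `Oc1ccc(-c2cc(-c3ccccn3)nc(-c3ccccc3Cl)c2)cc1` — "not determined" (no result reported)
compound 3 `Oc1ccc(-c2cc(-c3ccc(Cl)cc3)nc(-c3cccnc3)c2)cc1` — 27500 nM

Going by the values given here, only one number exists in an ADME assay on HEK293 cells (Homo sapiens) for cytotoxicity, read by CCK-8 assay and cell counting, with a stated time of 2 days; on this read-out lower numbers stand for stronger inhibition and higher numbers for weaker inhibition: compound 3 gives 27500 nM, a weak effect on the cells. Among the compounds with values here, compound 2 stands at "not determined" (no result reported) in this assay, and compound 1 likewise gives "not determined" (no result reported), so no step between measured compounds can be drawn. Where compound 2 sits relative to compound 3 on this read-out is therefore unknown.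

Compound 4 `Oc1ccc(-c2cc(-c3cccs3)nc(-c3ccccc3Cl)c2)cc1` arises from compound 2 through (thiophen-2-yl in place of pyridin-2-yl on an aromatic carbon). Within the data shown here, no measured step in this assay offers a size or a direction for this change. Among the measured compounds shown here, the working assumption is a step from compound 2 to compound 4 of no more than the usual scatter, in either direction, but this rests on nothing beyond the single result of compound 3, which showed 27500 nM in this assay. The weak effect of compound 3 is taken as the anchor for the whole set, since every compound shares the same core with a 4-hydroxyphenyl group and a chlorophenyl group.

Compound 4 is expected at 30000 nM, within a range of 8000 nM to 100000 nM.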

Compound 4, half-maximal inhibitory concentration: 5220 nM
Compound 4: the middle estimate sits 5.7-fold (0.76 log units) above what was measured, outside the stated range (below it).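

No step can be read in this assay from compound 2, which stands at "not determined" (no result reported), to compound 4, which gives 5220 nM. The compounds shown leave open what thiophen-2-yl in place of pyridin-2-yl does to the cytotoxicity read-out. No supporting data bear on the result of compound 4.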